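Replacing Isopropyl with Methoxycarbonyl on a Shared Core

The compounds below may be only part of what the source reports. "The series", "measured", "known", "first", "only" and "open" are said of these compounds alone.

compound 1 `CC(C)c1ccc(N2C(=O)C=CC2OCC(F)(F)F)cc1` — 6620 nM
compound 2 `CC(C)NC1CC(=O)N(c2ccc(F)c(Cl)c2)C1OCC(F)(F)F` — 10500 nM

In a functional assay on K562 cells (Homo sapiens) for inhibition (a higher number here means a weaker inhibitor, a lower number a stronger inhibitor), compound 1 gives 6620 nM, the lowest of the two numbers shown. Compound 2 gives 10500 nM, and the gap between the two lies within the scatter, so neither can be called the stronger inhibitor. Compound 3 `COC(=O)c1ccc(N2C(=O)C=CC2OCC(F)(F)F)cc1` has not yet been measured. It differs from compound 1 by methoxycarbonyl in place of isopropyl on an aromatic carbon. Among the measured compounds shown here, no step between measured compounds is available to show how such a change has moved the numbers. Compound 3 is therefore expected to give 9000 nM, with a range from 3000 nM to 30000 nM. The step of a 1.4-fold higher number from compound 1 to compound 3 (0.13 log units; within the scatter) is expected to stay near the scatter, with no firm direction.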

Compound 3, half-maximal inhibitory concentration: 14700 nM
The estimate for compound 3 lay 1.6-fold (0.21 log units) below the measured number, and the stated range covers the measured number.
By their numbers in this assay, from the lowest: compounds 1, 2 and 3 (each within the scatter of the next, the first and the last beyond it).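

Methoxycarbonyl in place of isopropyl, on an aromatic carbon para to a large group, gives the first readable step at this position in this assay: a 2.2-fold higher number from compound 1 to compound 3 (0.35 log units; beyond the scatter). The number at this position therefore depends on the group it carries, and here methoxycarbonyl goes with a weaker inhibitor than isopropyl, though the step is modest. Nothing available explains this shift.

From the compounds shown here alone, whether an amine, a carboxylic acid or a longer chain at this position would give a lower number remains open. A single step also cannot show whether this change would act the same way on another core.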